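Diaryl ether series: stability outlook for compound 4

The source may report more compounds than this note shows. Statements on the series, on what has been measured and on what is new or still open speak of the compounds shown alone.

Measured so far, in an ADME assay on S9 fraction from liver (Rattus norvegicus) for metabolic stability, read by LC-MS, using NADPH, with a stated time of 30 min; on this read-out higher numbers stand for a more stable compound and lower numbers for a less stable compound:
compound 1, `CCCCCCCCc1ccc(OC(C)C(=O)Cn2nnc(-c3ccc(Cl)cc3)n2)cc1`, gives 72%;
compound 2, `CC(Oc1ccc(Oc2ccc(F)cc2)cc1)C(=O)Cn1nnc(-c2ccc(Cl)cc2)n1`, gives < 5%;
compound 3, `CC(Oc1ccc(Oc2ccc(Cl)cc2)cc1)C(=O)Cn1nnc(-c2ccc(Cl)cc2)n1`, gives < 5%.

Among the compounds with values here, compound 1, with its octyl chain, is the only member that returns a number. The value of compound 2 is a limit of the assay. The value of compound 3 is likewise a limit of the assay, so compound 3 stands at the floor of the numbers shown, which amounts to the limit of < 5% in this assay, at which 2 of the 3 values shown sit.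

Two steps are readable: a number at least 67 percentage points lower from compound 1 to compound 2 (beyond the scatter) and a number at least 67 percentage points lower from compound 1 to compound 3 (beyond the scatter), both large drops on replacing the octyl chain by a halogenated phenoxy group. The step within the phenoxy pair, a step that the two limits leave unreadable from compound 2 to compound 3, cannot be sized, since both ends sit at the limit.

Compound 4, `CC(Oc1ccc(Oc2ccc(C(F)(F)F)cc2)cc1)C(=O)Cn1nnc(-c2ccc(Cl)cc2)n1`, differs from compound 3 by trifluoromethyl in place of chloro on an aromatic carbon. Within the data shown here, the only step that bears on this kind of change is the halogen swap from compound 2 to compound 3, which left both compounds at the limit, so no step beyond the scatter is expected, and a step that the limit leaves unreadable from compound 3 to compound 4 is the estimated change. Compound 4 is therefore expected to remain at or near the limit, estimated at 4% with a range of 0% to 18%.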

Compound 4, percent of the compound remaining: 9%
Compound 4: middle estimate off by 5 percentage points, on the low side, within the range that was stated.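

Compound 4 is the only member shown with a substituted phenoxy group that returns a number rather than a limit in this assay, which places trifluoromethyl, on an aromatic carbon para to a large group, off the floor held by the two halogens: the limit of < 5% in this assay, at which 2 of the 4 values shown sit.

Against the halogens the change reads as a number at least 4 percentage points higher from compound 3 to compound 4 (that floor lies within the scatter) and as a number at least 4 percentage points higher from compound 2 to compound 4 (that floor lies within the scatter), so these readings do not establish a real gain in stability for trifluoromethyl over chloro or fluoro. The larger gap stays in place, with a number 63 percentage points lower from compound 1 to compound 4 (beyond the scatter), so 4-(trifluoromethyl)phenoxy does not bring the series close to the octyl compound.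

Still open, from the compounds shown here alone, is whether any other para group on this ring, such as a nitrile, a carboxylic acid or a shorter alkyl chain, would return a number between that of compound 4 and that of compound 1. Also open is whether the stability seen with octyl belongs to the alkyl chain itself or to the absence of a phenoxy group, a question the shown pairs cannot separate.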